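The source may hold more compounds than are shown below. What is called first, only, known or untested is meant among the compounds shown, and "the series" means these compounds.

Compound 1 `COc1nc2ccccc2cc1/C=C/c1noc(-c2cccc(C)c2)n1`: > 230000 nM
Compound 2 `COc1cccc(-c2nc(/C=C/c3cc4ccccc4nc3OC)no2)c1`: > 220000 nM

In an ADME assay on HepG2 cells (Homo sapiens) for cytotoxicity, read by sulforhodamine B assay, with a stated time of 48 h (on this read-out lower numbers stand for higher toxicity in this test and higher numbers for lower toxicity in this test), compound 1 shows only a limit, > 230000 nM. Compound 2 likewise shows only a limit, > 220000 nM. With both values at limits, the step that the two limits leave unreadable from compound 1 to compound 2 has no readable size, and compound 2 stands at the limit of > 220000 nM in this assay, at which 1 of the 2 values shown sits. Compound 3 `COCc1nc(/C=C/c2cc3ccccc3nc2OC)no1` differs from compound 2 by methoxymethyl in place of 3-methoxyphenyl on an aromatic carbon. Among the compounds with values here, the single measured step gives no size to lean on, so no shift beyond the scatter is expected in this assay. Compound 3 is therefore estimated at 200000 nM, within 50000 nM to 500000 nM. For compound 3 this means an expected step of an at least 1.1-fold lower number from compound 2 to compound 3 (0.04 log units; that floor lies within the scatter).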

Compound 3, half-maximal cytotoxic concentration: > 270000 nM
Compound 3 gave a limit, no number; the forecaster's own chance of this, stated with the estimate: 70%; middle value at least 1.3-fold (0.13 log units) from the limit.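

Within the data shown here, compound 2 and compound 3 each gave only a limit, as did compound 1, so no step between them can be read. Going by these compounds, the concentration at which any of the three becomes toxic remains open.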